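The source may hold more compounds than are shown below. What is called first, only, known or untested is meant among the compounds shown, and "the series" means these compounds.

Three compounds sharing one core have been examined in a functional assay on CHO-K1 cells for antagonist activity at melanin-concentrating hormone receptor 1 (Homo sapiens), read by inositol phosphate accumulation, with stated times of 10 min and 45 min; on this read-out lower numbers stand for stronger inhibition and higher numbers for weaker inhibition. Compound 1 `Cc1nc(N2CCC(N3CCOC3=O)CC2)nc2ccc(NC(=O)/C=C/c3ccc(OC(F)(F)F)cc3)cc12` gives 31 nM. Compound 2 `Cc1nc(NCCCNS(C)(=O)=O)nc2ccc(NC(=O)/C=C/c3ccc(OC(F)(F)F)cc3)cc12` gives 32 nM. Compound 3 `Cc1nc(N2CCC(O)CC2)nc2ccc(NC(=O)/C=C/c3ccc(Cl)cc3)cc12` gives 73 nM. Among these three numbers compound 1 stands lowest; compound 2 lies nearest to it, within the scatter, and compound 3 lies furthest, beyond the scatter, though compound 3 differs from compound 1 in two places, so its gap cannot be laid to a single change. Going by the values given here, the one single-point step, a 1.0-fold higher number from compound 1 to compound 2 (0.01 log units; within the scatter), shows that a large exchange on the aromatic carbon of the core left the number within the scatter.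

Compound 4 `Cc1nc(N2CCC(N3CCN(C)C3=O)CC2)nc2ccc(NC(=O)/C=C/c3ccc(OC(F)(F)F)cc3)cc12` carries a more modest change: 3-methyl-2-oxoimidazolidin-1-yl in place of 2-oxo-1,3-oxazolidin-3-yl on a saturated ring carbon. Among the compounds with values here, no measured step probes this ring exchange directly; the only step that bears on the same region of the molecule, from compound 1 to compound 2, was within the scatter. Compound 4 is therefore expected to show no step beyond the scatter, a 1.1-fold higher number from compound 1 to compound 4 (0.05 log units; within the scatter). The estimate for compound 4 in this assay is 35 nM, with a range from 15 nM to 80 nM.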

Compound 4, half-maximal inhibitory concentration: 21 nM
The estimate for compound 4 lay 1.7-fold (0.22 log units) above the measured number, within the range that was stated.
By their numbers in this assay, from the lowest: compounds 4, 1 and 2 (each within the scatter of the next); then compound 3.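

Replacing 2-oxo-1,3-oxazolidin-3-yl with 3-methyl-2-oxoimidazolidin-1-yl on a saturated ring carbon gives, in this assay, a 1.5-fold lower number from compound 1 to compound 4 (0.17 log units; within the scatter), so this exchange of one five-membered non-aromatic ring for another stays within the scatter. The earlier single-point step replaced the whole group on an aromatic carbon of the core, whereas this one keeps the six-membered ring and alters only the five-membered ring it carries. Nothing shown offers a reason for this result.

The compounds shown leave open how a primary amine, a carboxylic acid or an open-chain acetamide would read on this saturated ring carbon. They also leave open whether an ethyl group could stand in place of the methyl of 3-methyl-2-oxoimidazolidin-1-yl without a step beyond the scatter.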